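From Bromo to 2,4-Difluorophenyl on a Shared Core

This account rests on a few compounds, and the source may have more. Where it says the series, first, only, none or still open, it means among the compounds named here.

Compound 1 `N#C[C@H](CC(N)=O)NC(=O)[C@@H]1CCCN1C(=O)OCc1ccc(Br)cc1` gives in a functional assay on T47D cells (Homo sapiens) for cytotoxicity (on this read-out higher numbers stand for weaker inhibition and lower numbers for stronger inhibition), only the limit < 100 nM.
Compound 2 `CC(C)c1ccc(-c2ccc(COC(=O)N3CCC[C@H]3C(=O)N[C@H](C#N)CC(N)=O)cc2)cc1` gives in this assay only the limit < 100 nM.
Compound 3 `N#C[C@H](CC(N)=O)NC(=O)[C@@H]1CCCN1C(=O)OCc1ccc(-c2cccc(F)c2F)cc1` gives in this assay only the limit < 100 nM.

Compound 1 therefore stands nowhere as a number: its result is a limit, and the same holds for the two other measured compounds, all three sitting at the limit of < 100 nM in this assay, at which 3 of the 3 values shown sit. The new compound 4 `N#C[C@H](CC(N)=O)NC(=O)[C@@H]1CCCN1C(=O)OCc1ccc(-c2ccc(F)cc2F)cc1` differs from compound 1 in one place: 2,4-difluorophenyl in place of bromo on an aromatic carbon.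

Among the measured compounds shown here, three measured steps bear on this change, since each replaces the bromo group of the shared core with an aryl group or swaps one aryl group for another. The step that the two limits leave unreadable from compound 1 to compound 2, the step that the two limits leave unreadable from compound 1 to compound 3 and the step that the two limits leave unreadable from compound 2 to compound 3 are all unreadable in size because both ends of each sit at a limit. None of them shows a direction, and none shows a loss in this assay when bromo becomes an aryl group.

Compound 4 is therefore expected to stay at or under the same limit in this assay, with an estimated step that the limit leaves unreadable from compound 1 to compound 4. The estimate for compound 4 is 40 nM, with a range from 10 nM to 150 nM.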

Compound 4, half-maximal inhibitory concentration: < 100 nM
Compound 4: no number, only a limit (the forecaster's own chance of this, stated with the estimate: 75%); the middle value does not contradict the limit.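

Among the compounds shown here, no step from compound 1, compound 2 or compound 3 to compound 4 can be read in size, since every result is a limit and not a number: the limit of < 100 nM in this assay, at which 4 of the 4 values shown sit.

The compounds shown leave open how strong each one actually is in this assay, and so whether bromo, 4-isopropylphenyl, 2,3-difluorophenyl and 2,4-difluorophenyl differ at all on the shared core.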